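Cytotoxicity of a new thiazolyl analogue in the series

The compounds below may be only part of what the source reports. "The series", "measured", "known", "first", "only" and "open" are said of these compounds alone.

Of the compounds shown here, three in a shared core have been measured in an ADME assay on PC-3 cells (Homo sapiens) for cytotoxicity, read by WST assay, tested at 100 uM; a higher number here means more inhibition at the concentration tested (going by the name of the read-out), a lower number less inhibition. Compound 1 `CC(C)(C)CC(=O)Nc1cccc(C(=O)N2CCCC(C(=O)Nc3ccc(Cl)cc3)C2)c1` gives 0%, compound 3 `O=C(c1ccccc1)c1cccc(C(=O)N2CCCC(C(=O)Nc3ccc(Cl)cc3)C2)c1` gives 0%, and compound 2 `O=C(Nc1cccc(CN2CCCC2)c1)C1CCCN(C(=O)c2cc(C(F)(F)F)cc(C(F)(F)F)c2)C1` gives 51%. Compound 2 therefore stands highest of the three, with both other numbers lying well beyond the scatter below it. Among the compounds with values here, the one step between neighbours, no change at the digits printed from compound 1 to compound 3 (within the scatter), concerns a different part of the molecule and leaves the read-out unchanged.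

Compound 4 `Cc1nc(-c2cccc(NC(=O)C3CCCN(C(=O)c4cc(C(F)(F)F)cc(C(F)(F)F)c4)C3)c2)cs1` is not yet measured. Its difference from compound 2 is 2-methyl-1,3-thiazol-4-yl in place of (pyrrolidin-1-yl)methyl on an aromatic carbon. Within the data shown here, no measured step touches this position or either of these two groups, so the expectation rests on compound 2 alone and on the fact that the two chloroanilide compounds sit at the floor of this assay. A change in the read-out is expected, most likely downward from compound 2, though its size cannot be anchored to a measured step. Compound 4 is thus estimated at 35% in this assay, within a range from 5% to 65%, which corresponds to an expected step of a number 16 percentage points lower from compound 2 to compound 4 (beyond the scatter).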

Compound 4, a percentage reported as inhibition, at one concentration (the size of the read-out at that concentration, not a potency): 1%
The estimate for compound 4 lay 34 percentage points above the measured number, and the stated range ends above it.
By their numbers in this assay, from the lowest: compounds 1, 3 and 4 (each within the scatter of the next); then compound 2.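

Within the data shown here, the step of a number 50 percentage points lower from compound 2 to compound 4 (beyond the scatter) in this assay is the first measured change at this position, on an aromatic carbon meta to a large group, and it shows that the read-out can depend heavily on the group held there. The size of the step goes with an exchange that leaves the heavy-atom count and the absence of net charge as they were: what differs in the computed comparison is that a five-membered non-aromatic ring with 1 hetero atom gives way to a five-membered aromatic ring with 2 hetero atoms, one of them sulfur, and the hydrogen-bond acceptor count rises by the difference printed for the two groups. No measurement at hand accounts for the step, so it stands as an observation without an explanation.

The compounds shown leave open whether the read-out follows the nitrogen of the (pyrrolidin-1-yl)methyl group or the group as a whole, a question that a dimethylaminomethyl group or a cyclopentylmethyl group at this place would address. They also leave open whether the same exchange would have a step of similar size on the core of compound 1.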